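The source may hold more compounds than are shown below. What is called first, only, known or untested is meant among the compounds shown, and "the series" means these compounds.

Measured in a functional assay on Venous blood for antagonist activity at C-X-C chemokine receptor type 3 (Homo sapiens), read by flow cytometry, with a stated time of 30 min, in the presence of a further agent that is not named here; a lower number here means a stronger inhibitor, a higher number a weaker inhibitor:
compound 1, `C[C@@H]1CN(c2sc(C(F)(F)F)nc2-c2nc3ccccc3[nH]2)CCN1C(=O)Cn1cccn1`: 191 nM
compound 2, `C[C@@H]1CN(c2sc(C(F)(F)F)nc2-c2nc3ccccc3[nH]2)CCN1C(=O)Cn1cnc2c1CCN(C)C2`: 135 nM
compound 3, `C[C@@H]1CN(c2sc(C(F)(F)F)nc2-c2nc3ccc(CO)cc3[nH]2)CCN1C(=O)Cn1cnc2cccnc21`: 92.4 nM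

Compound 3 gives the lowest of the three numbers. Compound 2 sits within the scatter of it, so the two cannot be ordered; compound 1 stands at a higher number, beyond the scatter.

Compound 4, `C[C@@H]1CN(c2sc(C(F)(F)F)nc2-c2nc3ccccc3[nH]2)CCN1C(=O)Cn1cnc2cccnc21`, differs from compound 3 on the shared core: hydrogen in place of hydroxymethyl on an aromatic carbon. Going by the values given here, the only measured step, a 1.4-fold lower number from compound 1 to compound 2 (0.15 log units; within the scatter), concerns the group on the saturated chain carbon bound to the carbonyl carbon, not the fused ring, and so does not bear on this change. Compounds 1 and 2 both carry the unsubstituted fused ring, but each also differs from compound 3 at the other end, so no clean comparison for the hydroxymethyl exists. The expectation is therefore no step beyond the scatter in this assay, perhaps a slightly higher number. Compound 4 is estimated at 125 nM with a range of 60 nM to 260 nM. This estimate means an expected step of a 1.4-fold higher number from compound 3 to compound 4 (0.13 log units; within the scatter).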

Compound 4, half-maximal inhibitory concentration: 70 nM
Compound 4: the middle estimate sits 1.8-fold (0.25 log units) above what was measured; the measured number falls inside the stated range.
By their numbers in this assay, from the lowest: compounds 4, 3, 2 and 1 (each within the scatter of the next, the first and the last beyond it).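

In this assay, the hydroxymethyl on the aromatic carbon now has a comparison that differs in that one place, and a 1.3-fold lower number from compound 3 to compound 4 (0.12 log units; within the scatter) shows that hydroxymethyl and hydrogen cannot be told apart there. Going by these compounds alone, on the saturated chain carbon bound to the carbonyl carbon, a 1.9-fold lower number from compound 2 to compound 4 (0.29 log units; within the scatter) leaves the groups of those two compounds unordered, while a 2.7-fold lower number from compound 1 to compound 4 (0.44 log units; beyond the scatter) is the first step at this place to go beyond the scatter, though only modestly. No measurement at hand gives a reason for any of these steps.

Going by these compounds, whether an amine, a carboxylic acid or a longer chain in place of hydroxymethyl on that aromatic carbon would hold the number in this range remains open. Also open, on these data alone, is whether hydroxymethyl would read the same alongside the groups of compound 1 or compound 2.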